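Shortening the chain of compound 2

This account rests on a few compounds, and the source may have more. Where it says the series, first, only, none or still open, it means among the compounds named here.

Measured in a functional assay on Huh-7 cells (Homo sapiens) for inhibition, read by MTT assay, with a stated time of 72 h; on this read-out lower numbers stand for stronger inhibition and higher numbers for weaker inhibition:
Compound 1 `Nc1ncnc2c1c(-c1cnc3[nH]ccc3c1)nn2CCCCCC(=O)NO`: > 100000 nM, a limit of the assay
Compound 2 `Nc1ncnc2c1c(-c1cnc3[nH]ccc3c1)nn2CCCCCCCCCC(=O)NO`: 10100 nM

Among the measured compounds shown here, compound 2 holds the only true number so far, since the single other result, for compound 1, is a limit and not a number. Compound 3 `Nc1ncnc2c1c(-c1cnc3[nH]ccc3c1)nn2CCCCCCC(=O)NO` has a shorter chain than compound 2: hydroxycarbamoyl in place of 3-(hydroxycarbamoyl)propyl on a saturated chain carbon, six bonds along the chain from an aromatic nitrogen. In words, hydroxycarbamoyl stands in place of 3-(hydroxycarbamoyl)propyl on a saturated chain carbon, six bonds along the chain from an aromatic nitrogen. Its chain length therefore falls between those of the two measured compounds.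

For the measured compounds named here, only one measured step bears on this change: an at least 9.9-fold lower number from compound 1 to compound 2 (0.99 log units; beyond the scatter). Compound 3 takes back most of the chain that this step added. Two compounds cannot establish a trend, and one of them offers only a limit, so the forecast is loose. A move to a higher number, meaning weaker inhibition, is expected in this assay, beyond the scatter. The expected size is a 5.0-fold higher number from compound 2 to compound 3 (0.69 log units; beyond the scatter). For compound 3 the estimated value is 50000 nM, with an expected range from 15000 nM to 170000 nM.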

Compound 3, half-maximal inhibitory concentration: 50900 nM
The estimate for compound 3 lay 1.0-fold (0.01 log units) below the measured number, within the range that was stated.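

In this assay, hydroxycarbamoyl in place of 3-(hydroxycarbamoyl)propyl on this saturated chain carbon gives a 5.0-fold higher number from compound 2 to compound 3 (0.70 log units; beyond the scatter). Among the compounds shown here, this is the first comparison with true numbers at both ends, so the weaker inhibition that comes with the shorter chain now has a measured size, where the earlier step offered only a floor. Compound 1 carries a limit and not a number, and the step to the intermediate chain, an at least 1.9-fold lower number from compound 1 to compound 3 (0.29 log units; that floor lies within the scatter), leaves it unreadable whether compound 3 truly differs from compound 1: the limit of > 100000 nM in this assay, at which 1 of the 3 values shown sits.

Compound 2, with the longest chain shown, still gives only 10100 nM, so it remains open whether a longer chain would lower the number further or whether the gain would stop or reverse. All the compounds shown end in the same hydroxycarbamoyl group, so it also remains open how much this end matters for the read-out, a question that a carboxylic acid or a primary amide at the end of the chain could address.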